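Methoxyphenyl in place of pyridyl on the benzamide

This account rests on a few compounds, and the source may have more. Where it says the series, first, only, none or still open, it means among the compounds named here.

Compound 3 `Cc1cccc(NC(=O)c2cc(F)cc(-c3cccnc3)c2)n1` gives 702 nM in an in vitro assay on HEK-293T cells for displacement of a labelled ligand from metabotropic glutamate receptor 5 (Rattus norvegicus), read by scintillation counting (on this read-out lower numbers stand for stronger inhibition and higher numbers for weaker inhibition), the highest of the three numbers to hand. Compound 1 `Cc1cccc(NC(=O)c2cccc(C#N)c2)n1`, which carries no such aryl group, gives 330 nM in this assay; compound 2 `N#Cc1cc(C#Cc2ccccn2)ccc1-c1ccc(F)cc1`, built on a different scaffold, gives 3 nM. The gap from compound 3 to compound 1 lies beyond the scatter, and the gap to compound 2 is much larger still. Compound 4 `COc1ccccc1-c1cc(F)cc(C(=O)Nc2cccc(C)n2)c1` differs from compound 3 by 2-methoxyphenyl in place of pyridin-3-yl on an aromatic carbon. Going by the values given here, no measured pair shows the effect of this exchange. Since compound 1 with 330 nM does better without any group there, the exchange is not expected to cost potency; a small gain or none beyond the scatter appears likeliest. Compound 4 is therefore estimated at 400 nM in this assay, between 120 nM and 1500 nM. The expected step is a 1.8-fold lower number from compound 3 to compound 4 (0.24 log units; within the scatter).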

Compound 4, inhibition constant: > 10000 nM
Compound 4: no number, only a limit (the forecaster's own chance of this, stated with the estimate: 5%); middle value at least 25-fold (1.39 log units) from the limit.
By their numbers in this assay, from the lowest: compound 2; then compound 1; then compound 3. At a limit, above all of these: compound 4.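

The change shows that this aromatic carbon, meta to a fluoro group, does not accept every aryl group: 2-methoxyphenyl in place of pyridin-3-yl gives an at least 14-fold higher number from compound 3 to compound 4 (1.15 log units; beyond the scatter). The two groups have the same hydrogen-bond donor and acceptor counts, so those counts do not separate them. The reading for compound 4 in this assay is a limit, not a number: the limit of > 10000 nM in this assay, at which 1 of the 4 values shown sits.

As far as these compounds go, it remains open whether the loss follows the removal of the ring nitrogen or the entry of the methoxy group. A plain phenyl group at this carbon would separate the two.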